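Ethyl in place of hydrogen: what to expect for compound 3

The compounds below may be only part of what the source reports. "The series", "measured", "known", "first", "only" and "open" are said of these compounds alone.

Measured so far in a functional assay (thoracic aorta, Rattus norvegicus, strain Wistar); on this read-out lower numbers stand for an effect already at smaller amounts and higher numbers for an effect only at larger amounts of compound:
compound 1, `O=C(Nc1nc2ccc([N+](=O)[O-])cc2s1)Nc1ccc(C(F)(F)F)cc1Cl`: 54300 nM
compound 2, `O=C(Nc1nc2ccccc2s1)Nc1ccc(C(F)(F)F)cc1Cl`: only the limit > 100000 nM

Compound 2 stands at the edge of the numbers shown: its value is a limit of this assay, not a number, as stated by the limit of > 100000 nM in this assay, at which 1 of the 2 values shown sits. Within the data shown here, the one measured step, hydrogen in place of nitro on an aromatic carbon, gives an at least 1.8-fold higher number from compound 1 to compound 2 (0.26 log units; that floor lies within the scatter), so within this pair the removal of the nitro group cannot be separated from the scatter.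

Compound 3, `CCc1ccc2nc(NC(=O)Nc3ccc(C(F)(F)F)cc3Cl)sc2c1`, differs from compound 2 by ethyl in place of hydrogen on an aromatic carbon. Among the measured compounds shown here, no measured step touches this position or this kind of change; the only step on record concerns a different group on the other ring. The expectation therefore rests on compound 2 alone, whose reading in this assay is a limit, so no step beyond the scatter is anticipated in either direction, with a wide range. The expected step is a number no higher from compound 2 to compound 3 (the limit leaves the size open). For compound 3 the estimate is 100000 nM, ranging from 30000 nM to 300000 nM.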

Compound 3, half-maximal effective concentration: > 100000 nM
Compound 3: only a limit was reported (the forecaster's own chance of this, stated with the estimate: 60%); the middle value sits exactly at the limit.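

In this assay compound 3 also returns a limit and not a number, > 100000 nM. The step from compound 2 to compound 3 cannot be read, because both compounds sit at the edge of the assay, so ethyl in place of hydrogen on this aromatic carbon has no measurable size here: the limit of > 100000 nM in this assay, at which 2 of the 3 values shown sit. Ethyl in place of nitro at the same aromatic carbon gives an at least 1.8-fold higher number from compound 1 to compound 3 (0.26 log units; that floor lies within the scatter), so this change, like the removal of the nitro group, cannot be separated from the scatter.

The compounds shown leave open whether the nitro group of compound 1, which gives 54300 nM, reflects anything specific to that group, and whether any other group on this aromatic carbon gives a number at all in this assay. As far as these compounds go, an amine or a carboxylic acid at this place, or a chain longer than ethyl, would test whether readings stay at the limit, and the effect of ethyl itself stays unknown until a compound reads as a number on both sides of the change.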